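Chloro in Place of Hydrogen: Expecting Compound 3

The source may report more compounds than this note shows. Statements on the series, on what has been measured and on what is new or still open speak of the compounds shown alone.

Compound 1, `COc1cc(/C=C/C(=O)c2cccc(-n3cc(-c4ccccc4)[nH]c3=O)c2)ccc1O`, gives 2780 nM in a functional assay on BT-549 cells (Homo sapiens) for inhibition; on this read-out lower numbers stand for stronger inhibition of growth and higher numbers for weaker inhibition of growth.
Compound 2, `O=C(/C=C/c1cccc(O)c1)c1cccc(-n2cc(-c3ccccc3)[nH]c2=O)c1`, gives 9320 nM in this assay.

Compound 2 carries the highest of the two numbers, separated from compound 1 by the step of a 3.4-fold higher number from compound 1 to compound 2 (0.53 log units; beyond the scatter). Compound 3, `O=C(/C=C/c1cccc(O)c1)c1cccc(-n2cc(-c3ccc(Cl)cc3)[nH]c2=O)c1`, differs from compound 2 by chloro in place of hydrogen on an aromatic carbon. Going by the values given here, no measured step touches that ring; the single step known, a 3.4-fold higher number from compound 1 to compound 2 (0.53 log units; beyond the scatter), concerns the hydroxyphenyl end of the chain, so it offers no guide here. Compound 3 is therefore expected to show no step beyond the scatter. Compound 3 is estimated at 9000 nM in this assay, within 3000 nM to 27000 nM. This expected step is a 1.0-fold lower number from compound 2 to compound 3 (0.02 log units; within the scatter).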

Compound 3, concentration for 50% growth inhibition: 1450 nM
Compound 3: middle estimate off by 6.2-fold (0.79 log units), on the high side, outside the stated range (below it).
By their numbers in this assay, from the lowest: compounds 3 and 1 (each within the scatter of the next); then compound 2.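

In this assay the change from phenyl to 4-chlorophenyl brings a 6.4-fold lower number from compound 2 to compound 3 (0.81 log units; beyond the scatter), so the ring left untouched by the earlier pair also bears on growth inhibition, not only the hydroxyphenyl end of the chain. A single chlorine, para to a large group, is enough for a step beyond the scatter. Nothing available explains this step.

The compounds shown leave open whether a fluoro, methoxy or amine group at that place would act as chloro does. They also leave open whether chloro would bring a similar step on compound 1.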